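The source may hold more compounds than are shown below. What is called first, only, known or untested is meant among the compounds shown, and "the series" means these compounds.

Measured in an ADME assay on BHK cells (Mesocricetus auratus) for cytotoxicity, read by MTT assay, with a stated time of 96 h; on this read-out lower numbers stand for higher toxicity in this test and higher numbers for lower toxicity in this test:
Compound 1 `O=[N+]([O-])c1ccc(-c2nc3ccccc3[nH]2)c([N+](=O)[O-])c1`: > 100000 nM
Compound 2 `COc1ccc(-c2nc3cc(C(F)(F)F)ccc3[nH]2)c(OC)c1`: > 100000 nM
Compound 3 `COc1ccc(-c2nc3cc(C(F)(F)F)ccc3[nH]2)c(OC)c1OC`: 32000 nM

The entry for compound 1 is a limit of the assay, not a number. The entry for compound 2 is also only a limit. For the measured compounds named here, that leaves compound 3, at 32000 nM, as the only actual number in the set. The common ceiling is the limit of > 100000 nM in this assay, at which 2 of the 3 values shown sit.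

Compound 4 `COc1ccc(-c2nc3cc(C(C)=O)ccc3[nH]2)c(OC)c1OC` keeps the structure of compound 3 except for one change, acetyl in place of trifluoromethyl on an aromatic carbon.

Going by the values given here, the only measured step is an at least 3.1-fold lower number from compound 2 to compound 3 (0.49 log units; beyond the scatter). It lies beyond the scatter, but it is a different change, methoxy in place of hydrogen on an aromatic carbon, so it says little about this swap and sets no size for it. Among the compounds with values here, no pair here shows the acetyl swap directly. The expectation in this assay therefore stays anchored on compound 3 at 32000 nM, with no step beyond the scatter foreseen and only a slight lean toward a higher number. The expected change is a 1.3-fold higher number from compound 3 to compound 4 (0.10 log units; within the scatter). For compound 4 the estimated value is 40000 nM, expected to fall between 13000 nM and 100000 nM.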

Compound 4, half-maximal cytotoxic concentration: > 100000 nM
Compound 4 ended at the assay's limit (the forecaster's own chance of this, stated with the estimate: 25%); middle value at least 2.5-fold (0.39 log units) away from the limit.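

In this assay, the swap at this position on the aromatic carbon gives an at least 3.1-fold higher number from compound 3 to compound 4 (0.49 log units; beyond the scatter), so a change here can move the read-out beyond the scatter, just as the added methoxy did earlier. From the compounds shown here alone, the true size of this step stays unknown, since the entry for compound 4 is a limit of the assay and not a number. Compound 3 now stands out as the only compound with an actual value, and both compounds that differ from it in one place, compound 2 and compound 4, sit at the ceiling, so the measurable toxicity seen here appears only with trifluoromethyl and the third methoxy present together: the limit of > 100000 nM in this assay, at which 3 of the 4 values shown sit.

Still open, going by these compounds, is how other groups at this position would read, for instance an amine, a carboxylic acid or a nitrile, and whether any of them would bring the number back down toward that of compound 3. Also open, on these data alone, is how compound 2 and compound 4 compare with each other, as they differ in more than one place and neither has an actual value.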